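The source may hold more compounds than are shown below. What is called first, only, known or untested is meant among the compounds shown, and "the series" means these compounds.

In an ADME assay on HeLa cells (Homo sapiens) for cytotoxicity, read by MTT assay (a lower number here means a stronger inhibitor, a higher number a weaker inhibitor), compound 1 (`COc1ccc(C[C@H]2COC(=O)[C@@H]2Cc2ccc(OCc3cn(-c4ccc(F)cc4)nn3)c(OC)c2)cc1OC`) gives >= 600000 nM, which is a limit and not a number. Compound 3 (`COc1ccc(-n2cc(COc3ccc(C[C@H]4C(=O)OC[C@@H]4Cc4ccc(OC)c(OC)c4)cc3OC)nn2)cc1`) gives >= 600000 nM, again a limit and not a number. Compound 2 (`COc1ccc(C[C@H]2COC(=O)[C@@H]2Cc2ccc(OCC(=O)N3CCCCC3)c(OC)c2)cc1OC`) gives a measured 293000 nM. Compound 3 therefore sits with compound 1 at the limit of >= 600000 nM in this assay, at which 2 of the 3 values shown sit.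

Compound 4 (`COc1ccc(C[C@H]2COC(=O)[C@@H]2Cc2ccc(OCc3cn(-c4ccc(Cl)cc4)nn3)c(OC)c2)cc1OC`) has chloro in place of methoxy on an aromatic carbon, the change from 4-methoxyphenyl to 4-chlorophenyl: chloro in place of methoxy on an aromatic carbon. The closest measured change, on an aromatic carbon too, is a step that the two limits leave unreadable from compound 1 to compound 3, so it gives no size to carry over. For the measured compounds named here, the one readable step is an at least 2.0-fold lower number from compound 1 to compound 2 (0.31 log units; beyond the scatter), but it replaces the whole 1-(4-fluorophenyl)-1H-1,2,3-triazol-4-yl group and bears only loosely on this smaller change. No step beyond the scatter is expected in this assay, in either direction, and a further limit is the likeliest report. The expected change is a number no higher from compound 3 to compound 4 (the limit leaves the size open). For compound 4 the estimated value is 600000 nM, with an expected range of 300000 nM to 900000 nM.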

Compound 4, half-maximal inhibitory concentration: 279000 nM
Estimate against measurement, compound 4: 2.2-fold (0.33 log units) above; the measured number lies below the stated range.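

Chloro in place of methoxy on the aromatic carbon para to a large group gives an at least 2.1-fold lower number from compound 3 to compound 4 (0.33 log units; beyond the scatter), the first readable step at this position in this assay. Chloro in place of fluoro on the same carbon gives an at least 2.1-fold lower number from compound 1 to compound 4 (0.33 log units; beyond the scatter), so a change at this one carbon is enough to move a triazole compound off the limit: the limit of >= 600000 nM in this assay, at which 2 of the 4 values shown sit. The exchange of (piperidin-1-yl)carbonyl for 1-(4-chlorophenyl)-1H-1,2,3-triazol-4-yl gives a 1.1-fold lower number from compound 2 to compound 4 (0.02 log units; within the scatter), so these two groups now read alike in this assay.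

Methoxy and fluoro both remain limits, so their order and the full size of either step stay unread. Going by these compounds, whether bromo, an amine or a carboxylic acid on this carbon would read like chloro remains open.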